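Truncating the biguanide of compound 1 to a guanidine

The source may report more compounds than this note shows. Statements on the series, on what has been measured and on what is new or still open speak of the compounds shown alone.

Measured:
- compound 1, `N=C(N)NC(=N)Nc1cc(Cl)cc(Cl)c1`: 1.8 nM in an assay for binding affinity to Serotonin 3 (5-HT3) receptor (Homo sapiens), read by radioligand binding; a higher number here means a weaker inhibitor, a lower number a stronger inhibitor
- compound 2, `N=C(N)NC(=N)Nc1cc(Cl)c(Cl)c(Cl)c1`: 2.7 nM in this assay

Among the measured compounds shown here, compound 1 holds the smaller of the two numbers, but the only measured step, a 1.5-fold higher number from compound 1 to compound 2 (0.18 log units; within the scatter), is within the scatter and concerns an aromatic substituent. Compound 3, `N=C(N)Nc1cc(Cl)cc(Cl)c1`, differs from compound 1 by a hydrogen atom in place of a group of 3 heavy atoms (1 carbon, 2 nitrogen; no ring), on an amine nitrogen. For the measured compounds named here, no measured step touches this part of the molecule, so the expectation rests on the size of the removed group alone: a loss in binding beyond the scatter is expected for compound 3, with a 22-fold higher number from compound 1 to compound 3 (1.35 log units; beyond the scatter). The estimate for compound 3 is 40 nM, within 8 nM to 200 nM.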

Compound 3, inhibition constant: 5 nM
Compound 3: the middle estimate sits 8.0-fold (0.90 log units) above what was measured; measured number below the stated range.
By their numbers in this assay, from the lowest: compounds 1, 2 and 3 (each within the scatter of the next, the first and the last beyond it).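

In this assay, the hydrogen in place of the group of 3 heavy atoms on the amine nitrogen gives a 2.8-fold higher number from compound 1 to compound 3 (0.44 log units; beyond the scatter), a modest step beyond the scatter. The guanidine of compound 3 therefore stays close to the biguanide of compound 1, and the full biguanide is not needed for binding in the nanomolar range. No supporting data explain the size of this step.

On these data alone, whether a methyl group or an amine in place of that hydrogen would hold the binding remains open. So does whether a further chloro on the guanidine series would behave as it does in the biguanides.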